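Allyl in Place of Cyclopropyl on the Amide Nitrogen

The source may report more compounds than this note shows. Statements on the series, on what has been measured and on what is new or still open speak of the compounds shown alone.

Compound 1 `C=CCNC(=O)/C(C)=C(/C)c1ccc(Cl)cc1`: 180 mg/kg
Compound 2 `C/C(C(=O)NC1CC1)=C(/C)c1ccc(Cl)cc1`: 350 mg/kg

Of the compounds shown here, two have been measured in a toxicity assay on the whole organism (strain Icem-CET (SPF Caw)) for cytotoxicity, with Mus musculus as the target; on this read-out lower numbers stand for an effect already at smaller amounts and higher numbers for an effect only at larger amounts of compound. Compound 1 gives 180 mg/kg in this assay, and compound 2 gives 350 mg/kg. Compound 2 holds the highest of the two numbers, with compound 1 as its nearest neighbour, and the gap between them lies within the usual scatter of the measurement, so neither can be set apart from the other.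

Compound 3 `C=CCNC(=O)/C(C)=C(\C)c1ccc(Cl)cc1` has not yet been measured in this assay. It differs from compound 2 in one place: allyl in place of cyclopropyl on an amide-type nitrogen. Going by the values given here, no measured pair shows the same change, so nothing about its size can be read off from the data. Given that the two measured compounds, with different groups on the amide nitrogen, sit within the scatter of each other, compound 3 is expected to fall in the same region, with a step of a 1.4-fold lower number from compound 2 to compound 3 (0.15 log units; within the scatter) that stays within the scatter. Compound 3 is estimated at 250 mg/kg in this assay, with a range from 120 mg/kg to 500 mg/kg.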

Compound 3, dose for half-maximal effect: 70 mg/kg
For compound 3 the middle estimate is 3.6-fold (0.55 log units) above the measured one; the whole stated range lies above it.
By their numbers in this assay, from the lowest: compound 3; then compounds 1 and 2 (each within the scatter of the next).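

In this assay the replacement of cyclopropyl by allyl on the amide-type nitrogen now shows a 5.0-fold lower number from compound 2 to compound 3 (0.70 log units; beyond the scatter) and so clears the scatter, which the two earlier compounds, impossible to tell apart, could not show. That step cannot be credited to the allyl group alone, as allyl is also present in compound 1, and there is still a 2.6-fold lower number from compound 1 to compound 3 (0.41 log units; beyond the scatter) with the group on the nitrogen unchanged. The drawn geometry of the double bond therefore matters in this series, with the lower number going to the E form in the one pair that isolates it, and this pair carries the weight of the reading: the fact that compounds 1 and 3 differ only in the configuration as drawn

What stays open is whether a cyclopropyl amide would respond in the same way to a change of double-bond geometry, as only one form of it appears among these compounds. Going by these compounds, it is equally open whether the gap between the two geometries would persist with a longer chain such as butyl on the nitrogen, or with an amide nitrogen carrying only hydrogen.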